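Hexyl in Place of (tert-butoxycarbonyl)amino

A few compounds are considered here, and "the series" means these few. Any claim that something is new, unique, unknown or untested is made for them only; others in the source may bear on it.

Of the compounds shown here, two have been measured in a functional assay on cells (Splenocyte, Mus musculus, strain BALB/c) for inhibition, read by scintillation counting and thymidine incorporation, with stated times of 48 h and 8 h; a higher number here means a weaker inhibitor, a lower number a stronger inhibitor. Compound 1 `COc1ccc(-c2nc(Cc3c[nH]c4ccccc34)no2)cc1` gives only > 50000 nM, which is a limit of the assay and not a number. For the measured compounds named here, compound 2 `COc1cc(-c2noc(-c3ccc(NC(=O)OC(C)(C)C)cc3)n2)cc(OC)c1OC` gives 1600 nM in this assay, the only number recorded, and the other entry is the limit of > 50000 nM in this assay, at which 1 of the 2 values shown sits. Compound 3 `CCCCCCc1ccc(-c2nc(-c3cc(OC)c(OC)c(OC)c3)no2)cc1` has not been measured. It differs from compound 2 in a single place: hexyl in place of (tert-butoxycarbonyl)amino on an aromatic carbon. The leaving group carries one hydrogen-bond donor and two hydrogen-bond acceptors, while the entering hexyl carries none. Going by the values given here, no step between two measured compounds is available, so the size of this change has no measured precedent here. In this assay the change is expected to be a modest one, with the estimated step from compound 2 to compound 3 being a 1.9-fold higher number from compound 2 to compound 3 (0.27 log units; within the scatter), within or near the scatter. Compound 3 is therefore estimated at 3000 nM, expected to fall between 800 nM and 12000 nM.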

Compound 3, half-maximal inhibitory concentration: 23800 nM
For compound 3 the middle estimate is 7.9-fold (0.90 log units) below the measured one, outside the stated range (above it).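

For the compounds shown here, the first measured step at this position shows that the group on this aromatic carbon, para to a large group, strongly affects the read-out in this assay: hexyl in place of (tert-butoxycarbonyl)amino gives a 15-fold higher number from compound 2 to compound 3 (1.17 log units; beyond the scatter). Even so, compound 3 still gives a measured number, 23800 nM, rather than a limit of the assay. Nothing in the data at hand accounts for the size of this step.

From the compounds shown here alone, it remains open how a free amine, a carboxylic acid or a shorter chain such as propyl on this carbon would compare with compound 2 and compound 3. Going by these compounds, it is also open whether the step would hold on another core, as compound 1 differs from both compounds in more than one place and offers no comparison.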